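Acetamide to ethylurea on the sulfonate ester series

The source may hold more compounds than are shown below. What is called first, only, known or untested is meant among the compounds shown, and "the series" means these compounds.

Three members of the series have numbers in a functional assay on HT-29 cells (Homo sapiens) for antiproliferative activity, read by sulforhodamine B assay, with a stated time of 48 h (on this read-out higher numbers stand for weaker inhibition and lower numbers for stronger inhibition), so far. Compound 1 `CC(=O)Nc1cccc(S(=O)(=O)Oc2ccccc2C(C)C)c1` gives 27000 nM in this assay, compound 2 `CC(=O)Nc1ccc(S(=O)(=O)Oc2ccccc2C(C)C)cc1` gives 23000 nM, and compound 3 `CC(=O)Nc1ccc(S(=O)(=O)Oc2ccccc2I)cc1` gives 23000 nM. Within the data shown here, the one single-point step measured, no change at the digits printed from compound 2 to compound 3 (within the scatter), replaces isopropyl with iodo on an aromatic carbon and stays within the scatter. Compound 3 thus sits level with compound 2 at the digits shown, the two together holding the lowest numbers of the three; compound 1 is the furthest from compound 3, and that gap too lies within the scatter.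

Compound 4 `CCNC(=O)Nc1ccc(S(=O)(=O)Oc2ccccc2I)cc1` is the next member and awaits this assay. Its difference from compound 3 is ethylamino in place of methyl on a carbonyl carbon, so the acetyl of the acetamido group becomes ethylcarbamoyl. Among the measured compounds shown here, no measured step in this set touches that part of the molecule: the only step available, no change at the digits printed from compound 2 to compound 3 (within the scatter), is at the other end of the structure and was flat. With nothing to point in either direction, the working expectation for compound 4 is a step of no change at the digits printed from compound 3 to compound 4 (within the scatter), that is no change beyond the scatter, and compound 4 is expected to give about 23000 nM, within the range 8000 nM to 65000 nM.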

Compound 4, half-maximal inhibitory concentration: 5300 nM
Beside the measured number, compound 4's estimate is 4.3-fold (0.64 log units) above it; measured number outside the range, below it.
By their numbers in this assay, from the lowest: compound 4; then compounds 2, 3 and 1 (each within the scatter of the next).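

In this assay, the carbonyl carbon of the acetamido group responds to substitution: ethylamino in place of methyl gives a 4.3-fold lower number from compound 3 to compound 4 (0.64 log units; beyond the scatter), whereas iodo in place of isopropyl on an aromatic carbon gave no change at the digits printed from compound 2 to compound 3 (within the scatter). Among these compounds, the change from acetyl to ethylcarbamoyl is therefore the first single-place change to move the number beyond the scatter, which makes the substituent on this carbonyl carbon a more informative point of variation than the aromatic carbon bearing iodo or isopropyl. No available evidence accounts for the lower number, so the change can be recorded only as an empirical step.

Going by these compounds, the exchange brings in nitrogen and extra carbon together, so it remains open whether the step follows the nitrogen, the ethyl chain or both; plain ethyl, methylamino and a longer chain such as propylamino on the same carbonyl carbon would separate these. On these data alone, it is also open whether ethylcarbamoyl gives a comparable step with isopropyl in place of iodo, as a partner for compound 2.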